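Amide aryl replacement on the shared core

The compounds below may be only part of what the source reports. "The series", "measured", "known", "first", "only" and "open" are said of these compounds alone.

Compound 1 `COC(=O)c1scc(-c2ccc(NC(=O)c3ccc(C#N)nc3)cc2)c1OC` carries 6-cyanopyridin-3-yl on the amide carbonyl carbon of the shared core. Within the data shown here, in a functional assay on MDA-MB-231 cells (Homo sapiens) for antiproliferative activity, read by MTT assay, with a stated time of 24 h (on this read-out lower numbers stand for stronger inhibition and higher numbers for weaker inhibition), compound 1 gives 28500 nM, the highest of the two numbers measured so far. Compound 2 `COC(=O)c1scc(-c2ccc(NC(=O)c3ccc4ccccc4c3)cc2)c1OC` has naphthalen-2-yl at the same carbonyl carbon; in this assay compound 2 gives 5250 nM, which is a 5.4-fold lower number from compound 1 to compound 2 (0.73 log units; beyond the scatter).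

Compound 3 `COC(=O)c1scc(-c2ccc(NC(=O)c3ccc(C(F)(F)F)cc3)cc2)c1OC` is not yet measured. It differs from compound 1 as follows: 4-(trifluoromethyl)phenyl in place of 6-cyanopyridin-3-yl on a carbonyl carbon. Among the measured compounds shown here, the only measured step that bears on this change is the one from compound 1 to compound 2, where the same 6-cyanopyridin-3-yl was exchanged for a carbon-only aromatic group and the number moved by a 5.4-fold lower number from compound 1 to compound 2 (0.73 log units; beyond the scatter). A move in the same direction, lower, is therefore expected for compound 3, though with a different entering group the size is uncertain and is taken as somewhat smaller than that seen with compound 2.

For compound 3 in this assay a value of 10000 nM is expected, within a range from 4000 nM to 25000 nM. The expected change is a 2.9-fold lower number from compound 1 to compound 3 (0.45 log units; beyond the scatter).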

Compound 3, half-maximal inhibitory concentration: 18300 nM
Beside the measured number, compound 3's estimate is 1.8-fold (0.26 log units) below it; low and high end bracket the measured number.
By their numbers in this assay, from the lowest: compound 2; then compounds 3 and 1 (each within the scatter of the next).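

In this assay, the step of a 1.6-fold lower number from compound 1 to compound 3 (0.19 log units; within the scatter) shows that replacing 6-cyanopyridin-3-yl with a six-membered aromatic ring of carbon only does not by itself reproduce the gain seen with naphthalen-2-yl, since compound 1 and compound 3 cannot be told apart here. The step of a 3.5-fold higher number from compound 2 to compound 3 (0.54 log units; beyond the scatter) separates the two carbon-only aromatic groups at this carbonyl carbon, so the lower number of compound 2 belongs to naphthalen-2-yl in particular and not to carbon-only aromatic groups as a class, with compound 3 going against any such general reading. No measurement shown here explains these differences between the groups on the amide carbonyl carbon.

Unsubstituted phenyl and quinolin-3-yl on the same carbonyl carbon remain open, and they could show whether the number of compound 2 tracks the naphthalen-2-yl shape or survives a ring nitrogen. Also open, going by these compounds, is whether any of this holds for other substituents on a phenyl ring, such as an amine or a carboxylic acid, or in cell lines other than the one used here.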